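Anilinopyrimidine imines: thiophene for ethoxycarbonyl on the imine carbon

A few compounds are considered here, and "the series" means these few. Any claim that something is new, unique, unknown or untested is made for them only; others in the source may bear on it.

Compound 2 `CCOC(=O)/C=N/c1cnc(Nc2ccc(S(N)(=O)=O)cc2)nc1NC(C)C` carries an ethoxycarbonyl on the imine carbon and a sulfonamide on the aniline. Within the data shown here, in a functional assay on HCT-116 cells (Homo sapiens) for antiproliferative activity, read by MTT assay (a higher number here means a weaker inhibitor, a lower number a stronger inhibitor), compound 2 gives 49100 nM, the only numeric reading in the set. Compound 1 `CC(C)Nc1nc(Nc2ccc(N3CCN(C)CC3)cc2)ncc1/N=C/c1cccs1` pairs the thiophene imine with a methylpiperazinyl aniline. For compound 1 this assay reports only a limit, > 100000 nM, (the limit of > 100000 nM in this assay, at which 1 of the 2 values shown sits). Among the measured compounds shown here, no pair differing in a single place has been measured, so no step size is known.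

Compound 3 `CC(C)Nc1nc(Nc2ccc(S(N)(=O)=O)cc2)ncc1/N=C/c1cccs1` keeps the sulfonamide aniline of compound 2 and changes the imine substituent: thiophen-2-yl in place of ethoxycarbonyl on a carbon with a double bond to nitrogen. Compound 1 already holds the thiophene imine, and its reading sits at the assay limit, which suggests the thiophene does not help here. The step is therefore expected to run toward weaker inhibition, of a size that may or may not exceed the usual scatter: a 1.7-fold higher number from compound 2 to compound 3 (0.24 log units; within the scatter). Compound 3 is estimated at 85000 nM in this assay, with a plausible range from 25000 nM to 300000 nM, and a fair chance that only a limit is returned.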

Compound 3, half-maximal inhibitory concentration: 82100 nM
For compound 3 the middle estimate is 1.0-fold (0.02 log units) above the measured one; the measured number falls inside the stated range.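

Thiophen-2-yl in place of ethoxycarbonyl on a carbon with a double bond to nitrogen, with the sulfonamide aniline held fixed, gives a 1.7-fold higher number from compound 2 to compound 3 (0.22 log units; within the scatter) in this assay, so this is the first step read at this position and it shows no shift beyond the scatter. With the thiophene imine held fixed, sulfamoyl in place of 4-methylpiperazin-1-yl on an aromatic carbon gives an at least 1.2-fold lower number from compound 1 to compound 3 (0.08 log units; that floor lies within the scatter), which shows no shift beyond the scatter that can be claimed for the aniline substituent either. The reading of compound 1 is a limit, so this second step is only a floor and its true size stays unknown: the limit of > 100000 nM in this assay, at which 1 of the 3 values shown sits.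

From the compounds shown here alone, how an amine or a carboxylic acid on the imine carbon, or a longer chain in place of the ethoxycarbonyl, would read in this assay remains open. Among these compounds, also open is whether the step at the imine carbon carries over to the methylpiperazinyl aniline of compound 1, as the one reading at the imine carbon pair rests on the sulfonamide aniline alone.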